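This account rests on a few compounds, and the source may have more. Where it says the series, first, only, none or still open, it means among the compounds named here.

Measured in a functional assay on HepG2 cells (Homo sapiens) for inhibition, read by MTT assay, with a stated time of 3 days; a lower number here means a stronger inhibitor, a higher number a weaker inhibitor:
- compound 1 `COc1cc(-c2nc3ccccc3s2)ccc1OCC(=O)NNC(=O)CCl`: 2890 nM
- compound 2 `COc1cc(-c2nc3ccccc3s2)ccc1OCC(=O)NNC(O)CN(C)CC(=O)O`: 3030 nM

In this assay, compound 1 gives 2890 nM. Among the compounds with values here, only one other measured value can be set against it, and the two lie within the scatter of each other, so neither stands apart.

Compound 3 `CC[C@H](C)[C@H](NCC(=O)NNC(=O)COc1ccc(-c2nc3ccccc3s2)cc1OC)C(=O)O` has not yet been measured. It departs from compound 1 as follows: (1-carboxy-2-methylbutyl)amino in place of chloro on a saturated chain carbon bound to a carbonyl carbon. In short, (1-carboxy-2-methylbutyl)amino stands in place of chloro on a saturated chain carbon bound to a carbonyl carbon.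

Within the data shown here, one measured step bears on this change: a 1.0-fold higher number from compound 1 to compound 2 (0.02 log units; within the scatter). That step also removes the chloromethyl end and brings in a group with an amino nitrogen and a carboxymethyl arm, yet the number does not move beyond the scatter. It is a single step, however, and it differs from the new change in the group that enters, so the guidance is thin. No shift beyond the scatter is therefore expected in this assay, and the estimated step is a 1.1-fold higher number from compound 1 to compound 3 (0.04 log units; within the scatter). For compound 3 the expected value is 3200 nM, with an estimated range of 1300 nM to 8000 nM.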

Compound 3, half-maximal inhibitory concentration: 3540 nM
Estimate against measurement, compound 3: 1.1-fold (0.04 log units) below, and the stated range covers the measured number.
By their numbers in this assay, from the lowest: compounds 1, 2 and 3 (each within the scatter of the next).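

In this assay, a 1.2-fold higher number from compound 1 to compound 3 (0.09 log units; within the scatter). This exchange replaces chloro, a single heavy atom, with (1-carboxy-2-methylbutyl)amino, which brings in 9 heavy atoms, 2 hydrogen-bond donors, 2 hydrogen-bond acceptors and 2 defined stereocentres, yet the two numbers stay within the scatter. Unlike the step to compound 2, which also altered the carbonyl, this one keeps the carbonyl and changes only the group on the saturated chain carbon bound to it, so it shows that this single substitution, taken alone, does not separate compound 3 from compound 1 in this assay. No measurement at hand accounts for this result.

The compounds shown leave open whether any group at this place would move the number beyond the scatter, for example a simple dimethylamino group, a methyl ester in place of the carboxylic acid, or a longer chain between the amine and the acid. They also leave open whether the amine or the carboxylic acid contributes anything separately, and whether the opposite configuration at the two stereocentres would give a different number.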